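This account rests on a few compounds, and the source may have more. Where it says the series, first, only, none or still open, it means among the compounds named here.

Measured in a functional assay on LNCaP cells (Homo sapiens) for antiproliferative activity; a lower number here means a stronger inhibitor, a higher number a weaker inhibitor:

- compound 1 `Cn1ncc(Cl)c1-c1cc(C(=O)N[C@@H]2CN[C@H](CC(O)CO)C[C@H]2c2ccc(Cl)c(Cl)c2)oc1Cl`: 70 nM
- compound 2 `Cn1ncc(Cl)c1-c1cc(C(=O)N[C@@H]2CN[C@H](CCCO)C[C@H]2c2ccc(Cl)c(Cl)c2)oc1Cl`: 210 nM
- compound 3 `Cn1ncc(Cl)c1-c1cc(C(=O)N[C@@H]2CN[C@H](CC(N)=O)C[C@H]2c2ccc(Cl)c(Cl)c2)oc1Cl`: 160 nM

Compound 3 stands in the upper part of this small range. The data show a 1.3-fold lower number from compound 2 to compound 3 (0.12 log units; within the scatter), a gap within the scatter, and a 2.3-fold higher number from compound 1 to compound 3 (0.36 log units; beyond the scatter), a gap beyond it.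

Compound 4 `Cn1ncc(Cl)c1-c1cc(C(=O)N[C@@H]2CN[C@H](CC(=O)NCC(O)CO)C[C@H]2c2ccc(Cl)c(Cl)c2)oc1Cl` follows from compound 3 by one change: 2,3-dihydroxypropyl in place of hydrogen on an amide-type nitrogen. Among the measured compounds shown here, no measured pair makes this exact change, so the evidence is indirect. The closest guide is the pair that differs by a hydroxy group on the chain, which shows a 3.0-fold higher number from compound 1 to compound 2 (0.48 log units; beyond the scatter), a modest step. For the measured compounds named here, the three measured compounds also show that the only one with two hydroxy groups on its chain, compound 1, has the lowest number at 70 nM. Compound 4 also has two hydroxy groups on its chain, but they sit further out on a longer chain, so this comparison is only a loose one.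

A small step toward a lower number is therefore expected, and it may not clear the scatter, with the estimate being a 1.7-fold lower number from compound 3 to compound 4 (0.23 log units; within the scatter). For compound 4 the estimated value is 95 nM, with an expected range of 35 nM to 260 nM.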

Compound 4, half-maximal inhibitory concentration: 660 nM
The estimate for compound 4 lay 6.9-fold (0.84 log units) below the measured number; measured number above the stated range.
By their numbers in this assay, from the lowest: compound 1; then compounds 3 and 2 (each within the scatter of the next); then compound 4.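

In this assay, among the compounds shown here, 2,3-dihydroxypropyl on the amide-type nitrogen gives a step that the earlier compounds, which varied only the short chain, did not show: a 4.1-fold higher number from compound 3 to compound 4 (0.62 log units; beyond the scatter), so substitution at this nitrogen is not neutral. The size of the change depends on the comparison, with a 3.1-fold higher number from compound 2 to compound 4 (0.50 log units; beyond the scatter) and a larger 9.4-fold higher number from compound 1 to compound 4 (0.97 log units; beyond the scatter), which shows that the dihydroxy unit of compound 1 does not carry its low number over to compound 4 when it is attached through the carbamoyl group. Within these four compounds, then, the hydroxy groups cannot be read on their own, apart from the chain that carries them, and nothing given here accounts for the rise.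

The compounds shown leave open whether any group on this nitrogen raises the number or whether this follows from 2,3-dihydroxypropyl in particular, a question that a methyl or a 2-hydroxyethyl on the same nitrogen would address. They also leave open how a carboxylic acid or an amine would compare with the carbamoyl group at the end of the chain.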